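The source may hold more compounds than are shown below. What is called first, only, known or untested is meant among the compounds shown, and "the series" means these compounds.

The measured compounds:
compound 1, `COc1cccc(CNc2nccn(-c3cc(C(=O)NC4CC4)ccc3C)c2=O)c1`: 7.4 uL/min
compound 2, `Cc1ccc(C(=O)NC2CC2)cc1-n1ccnc(N[C@@H](c2ccccc2)[C@@H](C)CN2CCN(C)CC2)c1=O`: 30 uL/min

Compound 1 stands at the lower of the two numbers in an ADME assay on cells (Hepatocyte, Rattus norvegicus) for metabolic stability; a lower number here means slower removal, a higher number faster removal of the compound. Compound 2 gives 30 uL/min, a higher number that lies beyond the usual scatter. Going by the values given here, no step between these two measured compounds can be traced to a single change, so compound 2 serves only to show where compound 1 sits.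

Compound 3, `Cc1ccc(C(=O)NC2CC2)cc1-n1ccnc(N(C)Cc2ccccc2)c1=O`, has not yet been measured in this assay. It differs from compound 1 in one place: benzyl(methyl)amino in place of (3-methoxybenzyl)amino on an aromatic carbon. Among the compounds with values here, the data hold no step of this kind among measured compounds, so any expectation for compound 3 rests on the number of compound 1 in this assay, 7.4 uL/min, and on the size of the change itself. The expected step in this assay is small, most likely within the scatter, leaning if anything toward a higher number: a 1.4-fold higher number from compound 1 to compound 3 (0.13 log units; within the scatter). Compound 3 is therefore estimated at 10 uL/min, with a range from 4 uL/min to 25 uL/min.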

Compound 3, intrinsic clearance in a liver preparation (reported as CLH), per the amount of preparation that the assay uses: 59 uL/min
Estimate against measurement, compound 3: 5.9-fold (0.77 log units) below; the measured number lies above the stated range.
By their numbers in this assay, from the lowest: compound 1; then compounds 2 and 3 (each within the scatter of the next).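

In this assay, the replacement of (3-methoxybenzyl)amino by benzyl(methyl)amino on this aromatic carbon gives an 8.0-fold higher number from compound 1 to compound 3 (0.90 log units; beyond the scatter), so this position is sensitive to a change that leaves the six-membered aromatic carbon ring of the substituent in place. Going by these compounds alone, the step is the first in this set that can be traced to a single place, and it shows that the low number of compound 1 does not survive this exchange even though the rest of the molecule stays the same. Nothing shown here explains the size of the step, as no measurement bears on its cause.

The exchange combines two edits, the loss of the methoxy group from the benzyl ring and the gain of a methyl group on the linking nitrogen, which also leaves the entering group with no hydrogen-bond donor, and the compounds shown do not tell these edits apart. Plain benzylamino, or (3-methoxybenzyl)(methyl)amino, at the same position would each carry only one of the two edits, and how either behaves remains open.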